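The source may report more compounds than this note shows. Statements on the series, on what has been measured and on what is new or still open speak of the compounds shown alone.

Of the compounds shown here, three that share one core have been tested in an in vitro assay on HEK385-7 cells for displacement of a labelled ligand from prostaglandin D2 receptor 2 (Homo sapiens); a higher number here means a weaker inhibitor, a lower number a stronger inhibitor. Compound 1 `O=C(O)Cc1sc(C(c2ccc(F)cc2)c2ccc(F)cc2)nc1-c1ccccc1` gives 16 nM, and compound 2 `O=C(O)Cc1sc(C(c2ccc(F)cc2)c2ccc(F)cc2)nc1-c1ccoc1` gives 14 nM. Compound 3 `NS(=O)(=O)c1ccc(-c2nc(C(c3ccc(F)cc3)c3ccc(F)cc3)sc2CC(=O)O)cc1` gives 1500 nM, the highest of the three numbers, which makes it the weakest inhibitor measured so far: the step of a 94-fold higher number from compound 1 to compound 3 (1.97 log units; beyond the scatter) and the step of a 110-fold higher number from compound 2 to compound 3 (2.03 log units; beyond the scatter) are both large and well beyond the scatter.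

Compound 4 `O=C(O)Cc1sc(C(c2ccc(F)cc2)c2ccc(F)cc2)nc1-c1ccnc(Cl)c1` has not yet been measured. Compared with compound 3, it carries a different group on the same aromatic carbon of the shared core: 2-chloropyridin-4-yl in place of 4-sulfamoylphenyl on an aromatic carbon.

The two measured steps that bear on this change both run toward compound 3. Adding the sulfamoyl group alone cost a large amount, and replacing the furan-3-yl by the 4-sulfamoylphenyl brought a loss of similar size. Compound 4 takes the sulfamoyl-bearing group away again and puts in a 2-chloropyridin-4-yl, an aromatic ring that, like the phenyl of compound 1 and the furan-3-yl of compound 2, carries no sulfamoyl. The step of a 60-fold lower number from compound 3 to compound 4 (1.78 log units; beyond the scatter) is therefore expected to be a large fall in the number, back toward the values of compounds 1 and 2. Compound 4 is estimated at 25 nM, with a likely range from 8 nM to 80 nM.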

Compound 4, half-maximal inhibitory concentration: 3.1 nM
Beside the measured number, compound 4's estimate is 8.1-fold (0.91 log units) above it, outside the stated range (below it).
By their numbers in this assay, from the lowest: compound 4; then compounds 2 and 1 (each within the scatter of the next); then compound 3.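

Going by these compounds alone, until now, the only comparison between rings without sulfamoyl at this position was phenyl and furan-3-yl, and compound 1 and compound 2 gave numbers within the scatter of each other, so that swap gave no sign that the group here could improve on them. In this assay, the 2-chloropyridin-4-yl changes that picture, giving a 5.2-fold lower number from compound 1 to compound 4 (0.71 log units; beyond the scatter) and a 4.5-fold lower number from compound 2 to compound 4 (0.65 log units; beyond the scatter), both modest but beyond the scatter, while a 480-fold lower number from compound 3 to compound 4 (2.68 log units; beyond the scatter) is large and shows that removing the 4-sulfamoylphenyl does more than return to the level of the earlier rings. Nothing measured here accounts for this gain.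

Compound 4 differs from compound 1 by both a ring nitrogen and a chlorine, so the compounds shown cannot say which of the two goes with the lower number; a plain pyridin-4-yl and a chlorophenyl would separate them. They also leave open whether the large loss in compound 3 belongs to sulfamoyl alone, or would also appear with another group on that phenyl, such as a methyl, an amine or a carboxylic acid.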